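A few compounds are considered here, and "the series" means these few. Any claim that something is new, unique, unknown or untested is made for them only; others in the source may bear on it.

In a functional assay on K562 cells (Homo sapiens) for cytotoxicity, read by MTT assay, with a stated time of 3 days (a lower number here means a stronger inhibitor, a higher number a weaker inhibitor), two compounds on a shared core have been measured. Compound 1 `N#Cc1c(Cl)nc(SCc2nc3ccccc3[nH]2)nc1-c1ccccc1`, with chloro on an aromatic carbon, gives 11.3 nM. Compound 2 `CCNc1nc(SCc2nc3ccccc3[nH]2)nc(-c2ccccc2)c1C#N`, with ethylamino in its place, gives 4.38 nM, the lowest of the two numbers. This is a 2.6-fold lower number from compound 1 to compound 2 (0.41 log units; beyond the scatter), a modest step beyond the scatter.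

Compound 3 `N#Cc1c(Nc2ccccn2)nc(SCc2nc3ccccc3[nH]2)nc1-c1ccccc1` keeps the core of compound 2 and alters only the group on the amino nitrogen: pyridin-2-yl in place of ethyl on a nitrogen on an aromatic ring. In words, pyridin-2-yl stands in place of ethyl on a nitrogen on an aromatic ring, so ethylamino becomes (pyridin-2-yl)amino.

Going by the values given here, only the one measured step bears on this change, and it replaced chloro rather than ethyl. Among the compounds with values here, no measured compound shows what an aromatic ring on that nitrogen does, so the expectation stays close to compound 2 and carries a wide range. The expected change is a 1.4-fold higher number from compound 2 to compound 3 (0.14 log units; within the scatter), which is no step beyond the scatter. The estimate for compound 3 is 6 nM, with an expected range from 1.5 nM to 25 nM.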

Compound 3, half-maximal inhibitory concentration: 7 nM
For compound 3 the middle estimate is 1.2-fold (0.07 log units) below the measured one; the range from low to high includes it.
By their numbers in this assay, from the lowest: compounds 2, 3 and 1 (each within the scatter of the next, the first and the last beyond it).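

In this assay, the step of a 1.6-fold higher number from compound 2 to compound 3 (0.20 log units; within the scatter) shows that the nitrogen on the aromatic ring can carry pyridin-2-yl, with its six-membered aromatic ring, in place of the two-carbon ethyl without a change that can be told from the scatter. The step of a 1.6-fold lower number from compound 1 to compound 3 (0.21 log units; within the scatter) also lies within the scatter, unlike a 2.6-fold lower number from compound 1 to compound 2 (0.41 log units; beyond the scatter), so the chloro compound 1 and the ethylamino compound 2 are separated, while the (pyridin-2-yl)amino compound 3 cannot be told from either one. Nothing in hand gives a measured reason for these numbers or shows how either group acts on the cells.

The compounds shown leave open whether the ring nitrogen of pyridin-2-yl matters at all, which phenyl on the same amino nitrogen would test directly. They also leave open how far this nitrogen accepts other groups, such as a longer chain like n-butyl or a saturated ring like cyclohexyl, and whether the plain unsubstituted amino group would give a number closer to compound 1 or to compound 2.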